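This account rests on a few compounds, and the source may have more. Where it says the series, first, only, none or still open, it means among the compounds named here.

Working notes on the series. The shared core is carried by compound 1 `COc1cc(OC)c2c(=O)cc(-c3ccc(OC4CCN(C)CC4)cc3)oc2c1`, compound 2 `COc1cc(OC)c2c(=O)cc(-c3ccc(OC4CCNCC4)cc3)oc2c1` and compound 3 `COc1cc(OC)c2c(=O)cc(-c3ccc(OCC(O)CN(C)C)cc3)oc2c1`. In a functional assay (Homo sapiens) for antiproliferative activity, read by resazurin assay, with a stated time of 48 h, tested at 20 uM (on this read-out higher numbers stand for a stronger effect at the one concentration tested and lower numbers for a weaker effect), compound 1 gives "not determined" (no result reported), and compound 2 gives "not determined" (no result reported), so no number is reported for either of them. Among the measured compounds shown here, the single number available comes from compound 3, which in this assay gives 71%. For the measured compounds named here, compound 3 therefore stands alone: its value is the only measured point and there is no pair of measured compounds differing in one place from which a step could be read.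

Compound 4 `COc1cc(OC)c2c(=O)cc(-c3ccc(OCC(O)CO)cc3)oc2c1` is the next entry and is to be measured in this assay. The change from compound 3 to compound 4 is hydroxy in place of dimethylamino on a saturated chain carbon, two bonds along the chain from an oxygen on a saturated carbon. Nothing in the measured set shows what a change at this place, on a saturated chain carbon two bonds along the chain from an oxygen on a saturated carbon, does to the read-out.

With no comparable step shown, the expectation for compound 4 rests on the value of compound 3 alone and is wide. The step from compound 3 to compound 4 is expected to be a number 21 percentage points lower from compound 3 to compound 4 (beyond the scatter), a moderate fall in inhibition rather than none, though a result within the scatter of compound 3 would not be surprising. Compound 4 is accordingly estimated at 50%, with a plausible range from 20% to 75%.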

Compound 4, a percentage reported as inhibition, at one concentration (the size of the read-out at that concentration, not a potency): 16%
Estimate against measurement, compound 4: 34 percentage points above; the whole stated range lies above it.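

Hydroxy in place of dimethylamino on a saturated chain carbon, two bonds along the chain from an oxygen on a saturated carbon, gives the first readable step of the series: in this assay the read-out is a number 55 percentage points lower from compound 3 to compound 4 (beyond the scatter) and the step counts as large. This position is therefore not indifferent to the group it carries, and on this single pair the inhibition seen with the 3-(dimethylamino)-2-hydroxypropyl chain is largely lost with the 2,3-dihydroxypropyl chain, although the rest of the structure is unchanged. Nothing shown here gives a reason for the size of this step.

The compounds shown leave open whether another amine at the chain end, such as diethylamino or methylamino, would behave like compound 3, and whether a carboxylic acid or a longer chain would behave like compound 4. Among the compounds shown here, compound 1 and compound 2 carry no number, so no step involving either of them can be read, and what their chains do to the read-out remains unknown.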